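The source may hold more compounds than are shown below. What is called first, only, known or untested is meant among the compounds shown, and "the series" means these compounds.

Of the compounds shown here, three have been measured so far in a functional assay on K562 cells (Homo sapiens) for cytotoxicity, read by trypan blue exclusion, with a stated time of 96 h (on this read-out higher numbers stand for weaker inhibition and lower numbers for stronger inhibition), where a smaller number means that less compound is needed for the same effect on the cells. Compound 1 `O=S(=O)(/C=C/c1ccccc1)Nc1ccc(Cl)cc1` gives 20000 nM, the highest number of the set, and compound 2 `COc1cc(OC)c(/C=C/S(=O)(=O)Nc2ccc(OC)c(OC(=O)C(C)(C)C3=C(C)C(=O)C=C(C)C3=O)c2)c(OC)c1` gives 8 nM, the lowest. Compound 3 `COC(=O)C(Nc1cc(NS(=O)(=O)/C=C/c2c(OC)cc(OC)cc2OC)ccc1OC)c1ccc(F)cc1` gives 2500 nM, the second highest of the three, and it lies clearly apart from both of the others.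

Compound 4 `COc1cc(OC)c(/C=C/S(=O)(=O)Nc2ccc(OC)c(NC(C(=O)O)c3ccc(Cl)cc3)c2)c(OC)c1` is the next to be considered, and it differs from compound 3 in one place: carboxy(4-chlorophenyl)methyl in place of (4-fluorophenyl)(methoxycarbonyl)methyl on a nitrogen on an aromatic ring. In words, this is carboxy(4-chlorophenyl)methyl in place of (4-fluorophenyl)(methoxycarbonyl)methyl on a nitrogen on an aromatic ring. Going by the values given here, no measured pair of compounds shows what a change of this kind does, so any forecast here is rough. Among the compounds with values here, the wide spread of values offers the only guide, and compound 2 at 8 nM shows how far below compound 3 a number can fall in this small set. In this assay the expected step is moderate and toward stronger inhibition, a 4.2-fold lower number from compound 3 to compound 4 (0.62 log units; beyond the scatter). For compound 4 the estimated value is 600 nM, with an expected range from 50 nM to 6000 nM.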

Compound 4, half-maximal inhibitory concentration: 15 nM
Compound 4: the middle estimate sits 40-fold (1.60 log units) above what was measured; the measured number lies below the stated range.
By their numbers in this assay, from the lowest: compounds 2 and 4 (each within the scatter of the next); then compound 3; then compound 1.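

In this assay the group on a nitrogen on an aromatic ring has a strong hold on the read-out: with the shared core unchanged, this one swap gives a 170-fold lower number from compound 3 to compound 4 (2.22 log units; beyond the scatter) and so counts as a large step toward stronger inhibition. The outgoing and incoming groups look much alike, each with one six-membered aromatic ring and one double bond outside it, so even a modest change of group at this place can move the number a long way. The swap is really two edits made together, as methoxycarbonyl gives way to carboxy, which brings a hydrogen-bond donor, and fluorine on the ring gives way to chlorine, and nothing available here explains the size of the step.

Which edit carries the step stays open, and telling them apart would take the carboxy group paired with 4-fluorophenyl, or methoxycarbonyl paired with 4-chlorophenyl. Also open, as far as these compounds go, is how other groups would fare at this place, such as a primary amide in place of the carboxy group or 4-bromophenyl in place of 4-chlorophenyl.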